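This account rests on a few compounds, and the source may have more. Where it says the series, first, only, none or still open, it means among the compounds named here.

Working notes on the series.

Three compounds have numbers in an assay on mitochondria (strain BALB/c) for inhibition of glycerol-3-phosphate acyltransferase 1, mitochondrial (Mus musculus), read by scintillation counting, with a stated time of 10 min; on this read-out higher numbers stand for weaker inhibition and lower numbers for stronger inhibition. Among the compounds with values here, compound 1 `CCCCCCCCS(=O)(=O)Nc1cc(-c2cccc(F)c2)ccc1C(=O)O` gives 32600 nM and compound 2 `CCCCCCCCS(=O)(=O)Nc1cc(-c2ccc(O)cc2)ccc1C(=O)O` gives 64800 nM; the only single-point step among them, a 2.0-fold higher number from compound 1 to compound 2 (0.30 log units; within the scatter), does not rise above the scatter. Compound 3 `CCCCCCCCS(=O)(=O)Nc1ccc(-c2cccc(Cl)c2)cc1C(=O)O` gives 8900 nM, the lowest of the three numbers, with compound 1 its nearest neighbour and compound 2 its furthest, both beyond the scatter. Compound 3 is built on a core that differs from the shared core of compounds 1 and 2, so its number cannot be tied to theirs by a single change.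

Compound 4 `CCCCCCCCS(=O)(=O)Nc1ccc(-c2ccccc2O)cc1C(=O)O` is the next compound for this assay. It differs from compound 3 in one place: 2-hydroxyphenyl in place of 3-chlorophenyl on an aromatic carbon. Within the data shown here, the one step that bears on this change is a 2.0-fold higher number from compound 1 to compound 2 (0.30 log units; within the scatter), a hydroxyphenyl for a halophenyl on a different core and at a different position within the phenyl, and it stayed within the scatter. A shift toward a higher number is therefore expected, modest in size, as a 2.2-fold higher number from compound 3 to compound 4 (0.35 log units; beyond the scatter) for compound 4. Compound 4 is estimated at 20000 nM, between 7000 nM and 60000 nM.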

Compound 4, half-maximal inhibitory concentration: 61700 nM
Beside the measured number, compound 4's estimate is 3.1-fold (0.49 log units) below it, outside the stated range (above it).
By their numbers in this assay, from the lowest: compound 3; then compounds 1, 4 and 2 (each within the scatter of the next).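

On the core of compound 3, in this assay, 2-hydroxyphenyl in place of 3-chlorophenyl gives a step beyond the scatter: a 6.9-fold higher number from compound 3 to compound 4 (0.84 log units; beyond the scatter). Within the data shown here, the earlier exchange of a halophenyl for a hydroxyphenyl, a 2.0-fold higher number from compound 1 to compound 2 (0.30 log units; within the scatter), stayed within the scatter, so this is the first sign that the group at this place, meta to a carboxy group and para to a large group, can move the number by more than the scatter. Nothing available here accounts for the size of the step or for its difference from the earlier one.

Still open, from the compounds shown here alone, is whether the step follows the loss of the chlorine, the arrival of the hydroxyl, or the place of either on the phenyl. A 3-hydroxyphenyl or a 2-chlorophenyl on the core of compound 3 would separate these, and an aminophenyl would test a different group at the same place.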